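The source may report more compounds than this note shows. Statements on the series, on what has been measured and on what is new or still open speak of the compounds shown alone.

In a functional assay on the whole organism (strain Kunming) with Mus musculus as the target, with a stated time of 0.5 h (a higher number here means that more compound is needed for the effect, a lower number that less compound is needed), compound 2 `COc1cc(OC)c(OC)cc1/C=C/COC(=O)/C=C/c1ccccc1Cl` gives 58.7 mg/kg and compound 1 `COc1ccccc1/C=C/C(=O)OC/C=C/c1cc(OC)c(OC)cc1OC` gives 39 mg/kg, so the two values lie within the scatter of each other. Compound 3 `COc1cc(OC)c(OC)cc1/C=C/COC(=O)/C=C/c1ccc(Cl)cc1` has not yet been measured. It differs from compound 2 as follows: 4-chlorophenyl in place of 2-chlorophenyl on a double-bonded chain carbon bound to a double-bonded chain carbon. This places 4-chlorophenyl where 2-chlorophenyl stood, on a double-bonded chain carbon bound to a double-bonded chain carbon, and the two compounds have the same atoms, joined differently. Among the measured compounds shown here, only one measured step bears on this change, and only indirectly: a 1.5-fold higher number from compound 1 to compound 2 (0.18 log units; within the scatter), for chloro in place of methoxy on an aromatic carbon. For the measured compounds named here, no measured pair compares these two chlorophenyl groups directly, so the data give no ground for expecting a real shift in either direction. The expected step is therefore a 1.1-fold lower number from compound 2 to compound 3 (0.03 log units; within the scatter), with nothing expected beyond the scatter. For compound 3 the estimated value is 55 mg/kg, with an expected range of 25 mg/kg to 125 mg/kg.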

Compound 3, dose for half-maximal effect: 53.4 mg/kg
The estimate for compound 3 lay 1.0-fold (0.01 log units) above the measured number, within the range that was stated.
By their numbers in this assay, from the lowest: compounds 1, 3 and 2 (each within the scatter of the next).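

In this assay, among the compounds shown here, the exchange of 2-chlorophenyl for 4-chlorophenyl on a double-bonded chain carbon bound to a double-bonded chain carbon gives a 1.1-fold lower number from compound 2 to compound 3 (0.04 log units; within the scatter) and so offers the first direct comparison of these two chlorophenyl groups, which lie within the scatter of each other. At the same place, 4-chlorophenyl in place of 2-methoxyphenyl gives a 1.4-fold higher number from compound 1 to compound 3 (0.14 log units; within the scatter) and is also within the scatter, so the 2-methoxyphenyl, 2-chlorophenyl and 4-chlorophenyl groups cannot be told apart here. No measurement at hand offers an explanation for this result.

Still open, going by these compounds, is whether a 4-nitrophenyl, a 4-aminophenyl or an unsubstituted phenyl group at this place would give a step beyond the scatter. The three compounds also leave open how changes elsewhere in the shared core would read.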